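The source may report more compounds than this note shows. Statements on the series, on what has been measured and on what is new or still open speak of the compounds shown alone.

Working notes on the series. The shared core is that of compound 1 `Cc1cc(N2CC[C@@H](C)[C@@H](N(C)c3ncnc4[nH]ccc34)C2)n2ncnc2n1`, which in a functional assay on BGC-823 cells (Homo sapiens) for inhibition, read by MTT assay, with a stated time of 72 h (a lower number here means a stronger inhibitor, a higher number a weaker inhibitor), gives 67400 nM. Compound 2 `Cc1cc(N2CC[C@@H](C)[C@@H](N(C)c3ncnc4[nH]ccc34)C2)n2nc(SCc3cc(Cl)ccc3Cl)nc2n1` adds a (2,5-dichlorobenzyl)sulfanyl on an aromatic carbon and gives 18900 nM, so that a 3.6-fold lower number from compound 1 to compound 2 (0.55 log units; beyond the scatter). Compound 3 `Cc1cc(N2CC[C@@H](C)[C@@H](N(C)c3ncnc4[nH]ccc34)C2)n2nc(SCCCc3ccccc3)nc2n1` carries a (3-phenylpropyl)sulfanyl at the same place. For compound 3 the result is > 100000 nM, which is a limit of the assay and not a number (the limit of > 100000 nM in this assay, at which 1 of the 3 values shown sits). Compound 3 therefore stands only as a floor among the values here: an at least 1.4-fold higher number from compound 1 to compound 3 (0.17 log units; that floor lies within the scatter), and an at least 5.2-fold higher number from compound 2 to compound 3 (0.72 log units; beyond the scatter).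

Compound 4 `Cc1cc(N2CC[C@@H](C)[C@@H](N(C)c3ncnc4[nH]ccc34)C2)n2nc(SCc3ccc(F)cc3)nc2n1` differs from compound 3 by 4-fluorophenyl in place of phenethyl on a saturated chain carbon bound to a sulfur. For the measured compounds named here, the step that bears on this is the one from compound 2 to compound 3, where the phenyl ring sat directly on the saturated chain carbon bound to sulfur and the number was lower; compound 4 returns to that arrangement, with 4-fluorophenyl rather than 2,5-dichlorophenyl. A lower number than that of compound 3 is therefore expected for compound 4 in this assay, an at least 2.5-fold lower number from compound 3 to compound 4 (0.39 log units; beyond the scatter), most likely not reaching the value of compound 2. Compound 4 is estimated at 40000 nM, within 15000 nM to 100000 nM.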

Compound 4, half-maximal inhibitory concentration: 44300 nM
The estimate for compound 4 lay 1.1-fold (0.04 log units) below the measured number; the measured number falls inside the stated range.
By their numbers in this assay, from the lowest: compound 2; then compounds 4 and 1 (each within the scatter of the next). At a limit, above all of these: compound 3.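

In this assay, the effect of the sulfanyl substituent now proves to depend on the aryl group as well as the chain: changing the aryl group alone gives a 2.3-fold higher number from compound 2 to compound 4 (0.37 log units; beyond the scatter), while (4-fluorobenzyl)sulfanyl in place of hydrogen on an aromatic carbon gives a 1.5-fold lower number from compound 1 to compound 4 (0.18 log units; within the scatter), so this group cannot be told from the hydrogen of the shared core. Relative to the (3-phenylpropyl)sulfanyl group, 4-fluorophenyl in place of phenethyl gives an at least 2.2-fold lower number from compound 3 to compound 4 (0.35 log units; beyond the scatter), which is a floor on the step and not its measured size. Compound 3 stands at a limit of the assay and not at a number: the limit of > 100000 nM in this assay, at which 1 of the 4 values shown sits.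

The compounds shown leave open which feature of the 2,5-dichlorobenzyl group carries its lower number, as the two aryl groups differ in both the halogen and its placement. An unsubstituted benzyl, a 4-chlorobenzyl, or a benzyl bearing an amine or a carboxylic acid at this place would test how far the trend extends, and a (2-phenylethyl)sulfanyl would show how the number moves with chain length.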